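The compounds below may be only part of what the source reports. "The series", "measured", "known", "first", "only" and "open" are said of these compounds alone.

Measured in a functional assay on HL-60 cells (Homo sapiens) for cytotoxicity, read by WST assay, with a stated time of 48 h; a higher number here means that more compound is needed for the effect, a lower number that less compound is needed:
- compound 1 `O=C1OC[C@H](Cc2ccccc2)[C@H]1Cc1ccccc1O`: 83000 nM
- compound 2 `O=C1OC[C@H](Cc2ccccc2)[C@H]1Cc1cccc(O)c1`: > 100000 nM (a limit, not a number)
- compound 3 `Cc1ccc(C[C@H]2C(=O)OC[C@@H]2Cc2ccccc2)cc1`: 44000 nM

Only compound 1 and compound 3 have true numbers here, and the two cannot be told apart: a 1.9-fold lower number from compound 1 to compound 3 (0.28 log units; within the scatter). Compound 2 gives only a limit, > 100000 nM. That leaves a clearer gap: an at least 2.2-fold lower number from compound 2 to compound 3 (0.35 log units; beyond the scatter).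

The next compound, compound 4 `O=C1OC[C@H](Cc2ccccc2)[C@H]1Cc1ccc(F)cc1`, keeps the shared core and changes one group: fluoro in place of methyl on an aromatic carbon. Fluoro takes the place of methyl on an aromatic carbon, para to a large group. Going by the values given here, no measured step makes this exact swap. The closest guides exchange the substituted phenyl group on the same saturated chain carbon. One of them, an at least 1.2-fold higher number from compound 1 to compound 2 (0.08 log units; that floor lies within the scatter), stays within the scatter, as does the step from the first comparison above. Among the compounds with values here, only the step to compound 3 from the limit goes beyond it, and only modestly. A clear shift in either direction is therefore not expected in this assay. The estimated step is a 1.1-fold higher number from compound 3 to compound 4 (0.06 log units; within the scatter). Compound 4 is estimated at 50000 nM, with an expected range of 24000 nM to 100000 nM.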

Compound 4, half-maximal effective concentration: 57000 nM
Compound 4: the middle estimate sits 1.1-fold (0.06 log units) below what was measured; measured number inside the range.
By their numbers in this assay, from the lowest: compounds 3, 4 and 1 (each within the scatter of the next). At a limit, above all of these: compound 2.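

On this aromatic carbon, para to a large group, fluoro and methyl cannot be told apart in this assay: a 1.3-fold higher number from compound 3 to compound 4 (0.11 log units; within the scatter). The 4-fluorophenyl group also stays within the scatter of the 2-hydroxyphenyl group, with a 1.5-fold lower number from compound 1 to compound 4 (0.16 log units; within the scatter). Compound 2 remains a limit, not a number, and the floor of its step does not clear the scatter, so even this gap is not established, unlike the one seen with the 4-methylphenyl group: an at least 1.7-fold lower number from compound 2 to compound 4 (0.24 log units; that floor lies within the scatter).

Going by these compounds, it remains open whether an amine, a carboxylic acid or a longer chain on this same aromatic carbon would move the number beyond the scatter. It is also open how far compound 2 really lies from the other three, since only its limit is available: the limit of > 100000 nM in this assay, at which 1 of the 4 values shown sits.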